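Adding a chloro group to compound 1

This account rests on a few compounds, and the source may have more. Where it says the series, first, only, none or still open, it means among the compounds named here.

- compound 1 `Cc1nc(-c2ccc(Cl)cc2)sc1C(=O)CSc1nc(-c2ccccc2)c(C#N)c(=O)[nH]1` gives 27600 nM
- compound 2 `COc1ccc(-c2nc(C)c(C(=O)CSc3nc(-c4ccc(OC)cc4)c(C#N)c(=O)[nH]3)s2)cc1` gives 25300 nM
- compound 3 `COc1cccc(-c2nc(SCC(=O)c3sc(-c4ccccc4)nc3C)[nH]c(=O)c2C#N)c1` gives 59700 nM

All three numbers come from a functional assay on U-87MG ATCC cells for antiproliferative activity against U-87 MG (Homo sapiens), read by MTT assay, with a stated time of 48 h (on this read-out higher numbers stand for weaker inhibition and lower numbers for stronger inhibition), and they sit fairly close together. Compound 1 (27600 nM) cannot be told apart from compound 2 (25300 nM), since the two lie within the usual scatter of each other. Compound 3 (59700 nM) stands beyond that scatter from both, with a higher number and so weaker inhibition.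

The next compound, compound 4 `Cc1nc(-c2ccc(Cl)cc2)sc1C(=O)CSc1nc(-c2cccc(Cl)c2)c(C#N)c(=O)[nH]1`, keeps everything in compound 1 except one spot. The change is chloro in place of hydrogen on an aromatic carbon and it puts chloro in place of hydrogen on an aromatic carbon, turning phenyl to 3-chlorophenyl.

Among the measured compounds shown here, no measured pair differs in this one place alone, so the data offer no direct guide to this change. In this assay the expected outcome is no shift beyond the scatter, and the estimated step of a 1.3-fold lower number from compound 1 to compound 4 (0.10 log units; within the scatter) is small. For compound 4 an estimated 22000 nM is expected, within a range of 9000 nM to 50000 nM across repeated measurements.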

Compound 4, half-maximal inhibitory concentration: 40100 nM
The estimate for compound 4 lay 1.8-fold (0.26 log units) below the measured number; measured number inside the range.
By their numbers in this assay, from the lowest: compounds 2, 1, 4 and 3 (each within the scatter of the next, the first and the last beyond it).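

In this assay, among the compounds shown here, chloro in place of hydrogen on an aromatic carbon, turning phenyl to 3-chlorophenyl, gives a 1.5-fold higher number from compound 1 to compound 4 (0.16 log units; within the scatter) and so gives the first comparison in which only one place differs. At this position, adding one chloro group to the ring produces no shift that can be separated from the normal variation between repeated measurements, so neither a gain nor a loss of inhibition can be claimed. Nothing available explains the size of this step or links it to any property of the chloro group.

For the compounds shown here, with chloro as the only group compared directly with hydrogen at this spot, it remains open whether an amine or a carboxylic acid there would produce a step beyond the scatter. On these data alone, it also remains open whether chloro on another carbon of the same ring would behave in the same way.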